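A Second Fluoro Added Beside a Fluorophenyl Group

The source may report more compounds than this note shows. Statements on the series, on what has been measured and on what is new or still open speak of the compounds shown alone.

Compound 1 `COc1cc2c(Oc3ccc(NC(=O)c4cc(-c5ccccc5)ccn4)cc3F)ccnc2cc1OCCCN1CCCC1` and compound 2 `COc1cc2c(Oc3ccc(NC(=O)c4cc(-c5ccccc5F)ccn4)cc3F)ccnc2cc1OCCCN1CCCC1` share one core, while compound 3 `COc1cc2c(Oc3ccc(NC(=O)c4nccc(-c5ccc(F)cc5)n4)cc3F)ccnc2cc1OCCCN1CCCCC1` and compound 4 `COc1cc2c(Oc3ccc(NC(=O)c4nccc(-c5ccc(F)cc5F)n4)cc3F)ccnc2cc1OCCCN1CCCCC1` share another; the difference between the two cores is not broken down here. In a functional assay on NCI-H460 cells (Homo sapiens) for cytotoxicity, read by MTT assay, with a stated time of 72 h (on this read-out lower numbers stand for stronger inhibition and higher numbers for weaker inhibition), compound 1 gives 130 nM, and compound 2 gives 140 nM. The change between them is fluoro in place of hydrogen on an aromatic carbon, and it made a 1.1-fold higher number from compound 1 to compound 2 (0.03 log units; within the scatter). In this assay compound 3 gives 240 nM. The change leading to compound 4 is fluoro in place of hydrogen on an aromatic carbon; it is the same kind of change as before, though here the place is also meta to a fluoro group. Resting on the earlier 1.1-fold higher number from compound 1 to compound 2 (0.03 log units; within the scatter), the step from compound 3 to compound 4 is expected to be a 1.1-fold higher number from compound 3 to compound 4 (0.03 log units; within the scatter). Compound 4 is therefore estimated at 260 nM in this assay, with a range from 130 nM to 520 nM.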

Compound 4, half-maximal inhibitory concentration: 550 nM
The estimate for compound 4 lay 2.1-fold (0.33 log units) below the measured number; measured number outside the range, above it.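

In this assay the new fluoro gave a 2.3-fold higher number from compound 3 to compound 4 (0.36 log units; beyond the scatter) as a modest step, and set beside the earlier step it does not separate from it: the same change on two cores in this assay, a 1.1-fold higher number (0.03 log units; within the scatter) from compound 1 to compound 2 and a 2.3-fold higher number (0.36 log units; beyond the scatter) from compound 3 to compound 4, 2.1-fold (0.33 log units) apart, within the scatter of two such steps
The data therefore give no ground for saying that this change acts differently on the two cores, even though only the newer step stands beyond the scatter. Nor do they prove that it carries over unchanged: each core offers a single pair, and only on the core of compound 3 is the new fluoro meta to a fluoro group.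

On these data alone, it remains open whether a chloro or methoxy group in the same place would give a similar step. As far as these compounds go, it is also open how a 2,4-difluorophenyl group would read on the core of compound 1.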